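Methyl for methoxy: expectation for compound 4

The source may hold more compounds than are shown below. What is called first, only, known or untested is meant among the compounds shown, and "the series" means these compounds.

Compound 1 `COc1ccc(C(=O)/C=C/c2cc(-c3cc(OC)c(OC)c(OC)c3)n3nc(-c4ccccc4)cc3n2)cc1` is one of three analogues measured in a functional assay on MDA-MB-231 cells (Homo sapiens) for antiproliferative activity, read by MTT assay, with a stated time of 24 h; on this read-out higher numbers stand for weaker inhibition and lower numbers for stronger inhibition. Compound 1 gives 13200 nM; compound 2 `COc1ccc(/C=C/C(=O)c2cc(-c3ccc(OC)c(OC)c3)n3nc(-c4ccccc4)cc3n2)cc1` gives 22000 nM, and compound 3 `COc1ccc(-c2cc(C(=O)/C=C/c3ccc(C)cc3)nc3cc(-c4ccccc4)nn23)cc1OC` gives 22600 nM. Of the three numbers that of compound 1 is the lowest, yet its gaps to compound 2 and to compound 3 both lie within the scatter, so the three stand level on this read-out.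

Compound 4 `COc1cc(-c2cc(/C=C/C(=O)c3ccc(C)cc3)nc3cc(-c4ccccc4)nn23)cc(OC)c1OC` is not yet measured. It differs from compound 1 in a single place: methyl in place of methoxy on an aromatic carbon.

Within the data shown here, one measured step bears directly on this change, the same exchange carried out on another member of the series: a 1.0-fold higher number from compound 2 to compound 3 (0.01 log units; within the scatter). That step left the number where it was. On that basis no step beyond the scatter is expected for compound 4 in this assay, in either direction; the expected step is a 1.0-fold higher number from compound 1 to compound 4 (0.01 log units; within the scatter).

Compound 4 is therefore estimated at 13500 nM, with a range of 6000 nM to 30000 nM. This expectation rests on compound 1 at 13200 nM and on the flat step seen between compound 2 and compound 3.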

Compound 4, half-maximal inhibitory concentration: 23900 nM
Compound 4: middle estimate off by 1.8-fold (0.25 log units), on the low side, and the stated range covers the measured number.
By their numbers in this assay, from the lowest: compounds 1, 2, 3 and 4 (each within the scatter of the next).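

In this assay, the change from (4-methoxyphenyl)carbonyl to (4-methylphenyl)carbonyl gives a 1.8-fold higher number from compound 1 to compound 4 (0.26 log units; within the scatter). This is a second reading of the exchange, and like the first it stays inside the scatter, so methoxy at this place, para to a large group, can be replaced by methyl without a step that can be read in this assay. The two readings also cannot be told apart, so the series gives no sign that the outcome of this change depends on the core: the same change on two cores in this assay, a 1.0-fold higher number (0.01 log units; within the scatter) from compound 2 to compound 3 and a 1.8-fold higher number (0.26 log units; within the scatter) from compound 1 to compound 4, 1.8-fold (0.25 log units) apart, within the scatter of two such steps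

The compounds shown carry only methoxy or methyl at this place, so it remains open whether an amine, a carboxylic acid or a longer chain such as ethoxy on the same aromatic carbon would give a step beyond the scatter. Nor can the four numbers, each within the scatter of the next, separate the other differences among these compounds, and a wider range of groups at this place would be needed before any preference there could be stated.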